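The source may hold more compounds than are shown below. What is called first, only, known or untested is meant among the compounds shown, and "the series" means these compounds.

Compound 1, `CSc1ccc(-c2nc3c(=O)n(C)c(=O)n(C)c3[nH]2)cc1`: 2 nM
Compound 2, `Cc1cccc(-c2nc3c(=O)n(C)c(=O)n(C)c3[nH]2)c1`: 13 nM
Compound 3, `C=CCn1c(=O)c2nc(-c3ccc(Cl)cc3N)[nH]c2n(CC=C)c1=O`: 0.8 nM

Of the compounds shown here, three built around the same core have been measured in an assay for binding affinity to adenosine receptor A1 (Bos taurus); a higher number here means a weaker inhibitor, a lower number a stronger inhibitor. Compound 1 stands second highest of the three numbers. Its nearest neighbour is compound 3, whose value of 0.8 nM lies lower by a margin beyond the scatter, and its furthest is compound 2, whose value of 13 nM lies higher by a larger margin, also beyond the scatter. None of these pairs differs in only one place, so no single step can be read from them.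

Compound 4, `Cn1c(=O)c2nc(-c3ccc(F)cc3)[nH]c2n(C)c1=O`, has not yet been measured. It differs from compound 1 by fluoro in place of methylsulfanyl on an aromatic carbon, the place being an aromatic carbon of a six-membered aromatic ring of carbon only, para to a large group. With no measured step of this kind in hand, a modest move toward a higher number in this assay is expected, of a size near the edge of the scatter rather than clearly beyond it. Compound 4 is therefore estimated at 5 nM, within a range from 1.5 nM to 20 nM, an expected step of a 2.5-fold higher number from compound 1 to compound 4 (0.40 log units; beyond the scatter).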

Compound 4, half-maximal inhibitory concentration: 3.5 nM
Estimate against measurement, compound 4: 1.4-fold (0.15 log units) above, within the range that was stated.
By their numbers in this assay, from the lowest: compound 3; then compounds 1 and 4 (each within the scatter of the next); then compound 2.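

In this assay the exchange of methylsulfanyl for fluoro on an aromatic carbon, para to a large group, gives a 1.8-fold higher number from compound 1 to compound 4 (0.24 log units; within the scatter) and so leaves the two compounds indistinguishable. Within the data shown here, this is the first single change that can be read. Among these compounds, none of the earlier compounds differed in only one place. At this position, on this core, the second heavy atom, the sulfur and the one hydrogen-bond acceptor that leave with methylsulfanyl can all go without a shift that stands clear of the usual scatter of the assay, though a single pair shows this for these two groups alone.

The compounds shown leave open whether the same place would tolerate an amine, a carboxylic acid or a longer chain such as butylsulfanyl, and whether fluoro would behave alike on a core carrying other groups on its ring nitrogens. Nothing at hand gives a reason why methylsulfanyl and fluoro stand so close together here.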